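Nitro to acetamido on the thiourea series

The source may report more compounds than this note shows. Statements on the series, on what has been measured and on what is new or still open speak of the compounds shown alone.

compound 1 (`C[C@@H](/N=C(\S)NCc1ccc(C(C)(C)C)cc1)c1ccc([N+](=O)[O-])cc1`) gives 580 nM
compound 2 (`C[C@H](/N=C(\S)NCc1ccc(C(C)(C)C)cc1)c1ccc([N+](=O)[O-])cc1`) gives 14700 nM
compound 3 (`CC(=O)Nc1ccc([C@@H](C)/N=C(\S)NCc2ccc(C(C)(C)C)cc2)cc1`) has not yet been measured

In a functional assay for inhibition, with Rattus norvegicus as the target (on this read-out higher numbers stand for weaker inhibition and lower numbers for stronger inhibition), compound 1 holds the lower of the two numbers at 580 nM, and compound 2 stands at 14700 nM. Compound 3 keeps the configuration of compound 1 but carries acetamido in place of nitro on an aromatic carbon, para to a large group (acetamido in place of nitro on an aromatic carbon). Within the data shown here, the only measured step, a 25-fold higher number from compound 1 to compound 2 (1.40 log units; beyond the scatter), is large, but it concerns configuration alone (the fact that compounds 1 and 2 differ only in the configuration as drawn). It shows that the configuration of compound 1 is worth keeping, yet it gives no size for a change of this group. A moderate move to a higher number in this assay is therefore expected, held loosely. The estimated change is a 2.6-fold higher number from compound 1 to compound 3 (0.41 log units; beyond the scatter), with wide uncertainty. For compound 3 the expected value is 1500 nM, with an estimated range from 250 nM to 9000 nM.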

Compound 3, half-maximal inhibitory concentration: 3600 nM
Estimate against measurement, compound 3: 2.4-fold (0.38 log units) below, within the range that was stated.
By their numbers in this assay, from the lowest: compound 1; then compound 3; then compound 2.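

In this assay, acetamido in place of nitro on an aromatic carbon, para to a large group, gives a 6.2-fold higher number from compound 1 to compound 3 (0.79 log units; beyond the scatter). Among these compounds, this is the first size for a change of group at this position: the step is modest but beyond the scatter, so the position does respond, and nitro gives the lower number of this pair. The entering acetamido carries a hydrogen-bond donor that nitro lacks, but this one pair cannot tie the step to that difference, and the earlier step, a 25-fold higher number from compound 1 to compound 2 (1.40 log units; beyond the scatter), says nothing about it, as it concerns configuration alone: the fact that compounds 1 and 2 differ only in the configuration as drawn

Still open, on these data alone, is where an amine or a methoxy group on this aromatic carbon would fall relative to nitro and acetamido. Also open, as far as these compounds go, is whether the advantage of the configuration of compound 1 carries over to the acetamido compounds.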